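This account rests on a few compounds, and the source may have more. Where it says the series, first, only, none or still open, it means among the compounds named here.

Compound 1 `CCN(CC)S(=O)(=O)c1ccc(NC(=O)c2ccccc2)c2ccccc12` and compound 2 `O=C(Nc1ccc(S(=O)(=O)N2CCCCC2)c2ccccc12)c1ccccc1` share the core of compound 3 `CCOC(=O)N1CCC(NS(=O)(=O)c2ccc(NC(=O)c3ccccc3)c3ccccc23)CC1` but carry a diethylamino or a piperidin-1-yl on the sulfonyl sulfur in place of the ethyl piperidine-1-carboxylate sulfonamide. In an assay on L1.2 cells for binding affinity to C-C chemokine receptor type 8 (Homo sapiens) (a higher number here means a weaker inhibitor, a lower number a stronger inhibitor), compound 1 reaches only a limit, > 30000 nM. Compound 2 likewise reaches only a limit in this assay, > 30000 nM. The step that the two limits leave unreadable from compound 1 to compound 2 is therefore not readable. Going by the values given here, compound 3 gives 0.17 nM in this assay, the single number in the set. The values of compound 1 and compound 2 sit at the limit (the limit of > 30000 nM in this assay, at which 2 of the 3 values shown sit). Compound 4 `CCOC(=O)N1CCC(NS(=O)(=O)c2ccc(NCc3ccccc3)c3ccccc23)CC1` differs from compound 3 in one place: benzyl in place of benzoyl on a nitrogen on an aromatic ring. Among the compounds with values here, no measured step touches the nitrogen on the aromatic ring; the only measured step, between compound 1 and compound 2, sits on the sulfonyl sulfur and is unreadable, so nothing measured bears on this change. The expectation for compound 4 is a loss, a 29-fold higher number from compound 3 to compound 4 (1.47 log units; beyond the scatter), estimated without support from any measured step. Compound 4 is expected at 5 nM, between 0.3 nM and 100 nM.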

Compound 4, inhibition constant: 45.6 nM
Compound 4: the middle estimate sits 9.1-fold (0.96 log units) below what was measured; low and high end bracket the measured number.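

In this assay, going by these compounds alone, the nitrogen on the aromatic ring gives the first readable step: benzyl in place of benzoyl produces a 270-fold higher number from compound 3 to compound 4 (2.43 log units; beyond the scatter). The benzamido group thus outperforms the benzylamino group in this pair, although compound 4 still gives a measured number, 45.6 nM, rather than a limit. Nothing measured here accounts for the size of this step.

On these data alone, whether the carbonyl itself carries the difference remains open, since the change also alters the link between the nitrogen and the phenyl ring; a benzenesulfonyl or a phenylcarbamoyl group on the same nitrogen would separate these readings. Also open, as far as these compounds go, is whether a smaller acetyl group, or a methoxy or chloro substituent on the phenyl ring of the benzoyl group, would hold the value of compound 3.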